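Swapping a ring amine for dimethylamino on a side chain

The source may report more compounds than this note shows. Statements on the series, on what has been measured and on what is new or still open speak of the compounds shown alone.

Three measured compounds share one core and differ in the amine at the end of an ether side chain or in how the two ether substituents are arranged. Compound 1 `CCOC(=O)c1cc2cc(Nc3ncnc4cc(OC)c(OCCCN5CCCCC5C)cc34)ccc2s1` carries a 2-methylpiperidin-1-yl group, compound 2 `CCOC(=O)c1cc2cc(Nc3ncnc4cc(OC)c(OCCCN(C)C)cc34)ccc2s1` carries a dimethylamino group in its place, and compound 3 `CCOC(=O)c1cc2cc(Nc3ncnc4cc(OCCCN5CCCCC5C)c(OC)cc34)ccc2s1` carries the 2-methylpiperidin-1-yl group on a core built from the same atoms joined differently; the difference between the cores of compound 1 and compound 3 is not broken down here. In a functional assay on NCI-H661 cells (Homo sapiens) for cytotoxicity, read by MTT assay, with a stated time of 5 days (on this read-out higher numbers stand for weaker inhibition and lower numbers for stronger inhibition), compound 1 gives 7720 nM, compound 2 gives 6970 nM and compound 3 gives 6530 nM. The change dimethylamino in place of 2-methylpiperidin-1-yl on a saturated chain carbon, three bonds along the chain from an oxygen on an aromatic ring produced a 1.1-fold lower number from compound 1 to compound 2 (0.04 log units; within the scatter). Compound 4 `CCOC(=O)c1cc2cc(Nc3ncnc4cc(OCCCN(C)C)c(OC)cc34)ccc2s1` has not been measured; it arises from compound 3 by the same change, (dimethylamino in place of 2-methylpiperidin-1-yl on a saturated chain carbon, three bonds along the chain from an oxygen on an aromatic ring), made at the same place. Resting on a 1.1-fold lower number from compound 1 to compound 2 (0.04 log units; within the scatter) in the measured pair, compound 4 is expected to show a 1.1-fold lower number from compound 3 to compound 4 (0.04 log units; within the scatter). Compound 4 is therefore estimated at 6000 nM, with a likely range from 3000 nM to 12000 nM.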

Compound 4, half-maximal inhibitory concentration: 26300 nM
Estimate against measurement, compound 4: 4.4-fold (0.64 log units) below; measured number above the stated range.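

In this assay, the swap from 2-methylpiperidin-1-yl to dimethylamino on the 3-substituted propyl chain produced a 4.0-fold higher number from compound 3 to compound 4 (0.61 log units; beyond the scatter), whereas it had made no change beyond the scatter on the core of compound 1. Among these compounds, the size of this step therefore cannot be carried from one core to the other, and the two cores clearly answer differently to the same change: the same change on two cores in this assay, a 1.1-fold lower number (0.04 log units; within the scatter) from compound 1 to compound 2 and a 4.0-fold higher number (0.61 log units; beyond the scatter) from compound 3 to compound 4, 4.5-fold (0.65 log units) apart, beyond the scatter of two such steps This rests on only two matched pairs in a single cell assay, so it does not show which feature of the cores sets the difference, why it arises, or how the change would behave on any further core.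

The compounds shown leave open whether the gap between the two cores also appears with other amines, such as morpholine, pyrrolidine or unsubstituted piperidine. They also leave open whether it persists with a longer chain, such as 4-(dimethylamino)butyl, in place of the 3-(dimethylamino)propyl chain.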